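Adding a methyl to a naphthyl-bearing analogue

This account rests on a few compounds, and the source may have more. Where it says the series, first, only, none or still open, it means among the compounds named here.

Measured compounds:
Compound 1 `Cc1ccnc2nc(-c3cccc(Cl)c3)cc(O)c12`: 31.6 nM
Compound 2 `Oc1cc(-c2ccc3ccccc3c2)nc2ncccc12`: 8320 nM
Compound 3 `Cc1cc(C)c2c(O)cc(-c3cccc(Cl)c3)nc2n1`: 170 nM

All three were tested in a functional assay on OVCAR-3 cells (Homo sapiens) for antiproliferative activity; on this read-out lower numbers stand for stronger inhibition of growth and higher numbers for weaker inhibition of growth. Compound 1 gives 31.6 nM and stands as the lowest number of the three. Compound 2 gives 8320 nM, the highest number of the three, well separated from both others. The difference between compound 1 and compound 2 is not broken down here. Compound 3 differs from compound 1 in one place, (methyl in place of hydrogen on an aromatic carbon), and the step of a 5.4-fold higher number from compound 1 to compound 3 (0.73 log units; beyond the scatter) shows that this methyl weakens growth inhibition to a modest degree.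

Compound 4 `Cc1ccnc2nc(-c3ccc4ccccc4c3)cc(O)c12` has not yet been measured in this assay. It differs from compound 2 in one place, (methyl in place of hydrogen on an aromatic carbon). Among the compounds with values here, this is the same kind of change as the one from compound 1 to compound 3, but not the same: here the methyl enters ortho to a fused ring and opposite the ring nitrogen, while in compound 3 it enters next to the ring nitrogen, meta to a methyl group and para to a fused ring. Within the data shown here, only one such step has been seen, so the expectation for compound 4 rests on it loosely. Compound 4 is expected to give about 6000 nM in this assay, within 1500 nM to 25000 nM, which means an estimated step of a 1.4-fold lower number from compound 2 to compound 4 (0.14 log units; within the scatter), smaller than the measured step from compound 1 to compound 3 since the place differs and compound 1 itself carries this methyl while giving 31.6 nM.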

Compound 4, concentration for 50% growth inhibition: 1290 nM
Compound 4: middle estimate off by 4.7-fold (0.67 log units), on the high side; the whole stated range lies above it.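

In this assay, the methyl in place of hydrogen on an aromatic carbon gives a 6.4-fold lower number from compound 2 to compound 4 (0.81 log units; beyond the scatter) and so goes with stronger inhibition of growth on this core, the reverse of what the same kind of change did in the earlier pair. Set side by side, the two steps show that neither the direction nor the size of this methyl change can simply be carried from one core to another in this series: the same change on two cores in this assay, a 5.4-fold higher number (0.73 log units; beyond the scatter) from compound 1 to compound 3 and a 6.4-fold lower number (0.81 log units; beyond the scatter) from compound 2 to compound 4, 35-fold (1.54 log units) apart, beyond the scatter of two such steps. This does not show what sets the two steps apart, since the methyl of compound 4 sits opposite the ring nitrogen while the methyl of compound 3 sits at a different place on its ring, and the two pairs also carry different aromatic groups, so two steps cannot separate the place of the methyl from the rest of the core.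

The compounds shown leave open whether the methyl at the place it holds in compound 4 would give the same step on the core of compound 3, where a second methyl is present. They also leave open how a larger or different group at that place, such as an ethyl, a methoxy or an amine, would compare with the methyl.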